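Trimming the amide of compound 2

The source may hold more compounds than are shown below. What is called first, only, known or untested is meant among the compounds shown, and "the series" means these compounds.

In a functional assay on BXPC-3 cells (Homo sapiens) for inhibition, read by MTT assay, with a stated time of 7 days (on this read-out higher numbers stand for weaker inhibition and lower numbers for stronger inhibition), compound 1 `CCN(CC)S(=O)(=O)c1ccc(S(=O)(=O)N2CCC[C@@H](C(=O)NC3CN(C(=O)C4CC4)C3)C2)cc1` gives 18500 nM. Compound 2 `CCN1CC(NC(=O)[C@@H]2CCCN(S(=O)(=O)c3ccc(S(=O)(=O)N(CC)CC)cc3)C2)C1` gives > 30000 nM, which is a limit and not a number. Compound 3 `CCN(CC)S(=O)(=O)c1ccc(S(=O)(=O)N2CCC[C@@H](C(=O)NC)C2)cc1` differs from compound 2 by methyl in place of 1-ethylazetidin-3-yl on an amide-type nitrogen, with methyl in place of 1-ethylazetidin-3-yl on an amide-type nitrogen. Among the compounds with values here, the only measured step bearing on this change is an at least 1.6-fold higher number from compound 1 to compound 2 (0.20 log units; that floor lies within the scatter), made within the group that leaves, so no step beyond the scatter is expected in this assay. The expected step is a number no higher from compound 2 to compound 3 (the limit leaves the size open). The estimate for compound 3 is 30000 nM, with an expected range of 14000 nM to 65000 nM.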

Compound 3, half-maximal inhibitory concentration: 13800 nM
Compound 3: the middle estimate sits 2.2-fold (0.34 log units) above what was measured; the whole stated range lies above it.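

In this assay, methyl in place of 1-ethylazetidin-3-yl on an amide-type nitrogen gives an at least 2.1-fold lower number from compound 2 to compound 3 (0.33 log units; beyond the scatter). Going by these compounds, the size of that step stays open because compound 2 stands at a limit and not a number: the limit of > 30000 nM in this assay, at which 1 of the 3 values shown sits. Methyl in place of 1-(cyclopropylcarbonyl)azetidin-3-yl gives a 1.3-fold lower number from compound 1 to compound 3 (0.13 log units; within the scatter), so at this position neither group is needed to hold activity at this level. The compounds shown leave open whether a longer chain, or one ending in an amine or a carboxylic acid, on this nitrogen would move the number beyond the scatter.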